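Half-life notes: difluoromethyl to trifluoroethyl on the ether oxygen

A few compounds are considered here, and "the series" means these few. Any claim that something is new, unique, unknown or untested is made for them only; others in the source may bear on it.

Compound 1 `COc1c(C)cnc(C[S+]([O-])c2nc3cc(OC(F)F)ccc3[nH]2)c1C`: 15 h
Compound 2 `COc1ccnc(C[S+]([O-])c2nc3cc(OC(F)F)ccc3[nH]2)c1C`: 3 h

In an ADME assay for pharmacokinetics, at pH 7.4 (on this read-out lower numbers stand for a shorter-lived compound and higher numbers for a longer-lived compound), compound 2 gives 3 h, the lower of the two numbers. Compound 1 gives 15 h. Going by the values given here, the only measured step is a 5.0-fold lower number from compound 1 to compound 2 (0.70 log units; beyond the scatter). Compound 3 `COc1ccnc(C[S+]([O-])c2nc3cc(OCC(F)(F)F)ccc3[nH]2)c1C` differs from compound 2 by 2,2,2-trifluoroethyl in place of difluoromethyl on an oxygen on an aromatic ring. Among the compounds with values here, the measured step concerns a methyl on an aromatic carbon, not the group on the oxygen, so no measured step bears on this change. With nothing to go on, no step beyond the scatter is expected: no change at the digits printed from compound 2 to compound 3 (within the scatter). Compound 3 is therefore estimated at 3 h, in the range 1.2 h to 8 h.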

Compound 3, half-life: 5 h
Compound 3: middle estimate off by 1.7-fold (0.22 log units), on the low side; low and high end bracket the measured number.
By their numbers in this assay, from the lowest: compounds 2 and 3 (each within the scatter of the next); then compound 1.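

In this assay, 2,2,2-trifluoroethyl in place of difluoromethyl on the oxygen gives a 1.7-fold higher number from compound 2 to compound 3 (0.22 log units; within the scatter), so this first reading at the oxygen shows no step beyond the scatter. The change adds heavy atoms, and the number stays within the scatter. No measurement on hand accounts for this reading.

Going by these compounds, whether the result holds with the methyl of compound 1 on the aromatic carbon remains open. So does the outcome for a plain ethyl, a longer chain or an amine-bearing chain on the same oxygen.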